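This account rests on a few compounds, and the source may have more. Where it says the series, first, only, none or still open, it means among the compounds named here.

Compounds measured so far:

Compound 1, `C=CCn1nc(-c2ccc(OC)cc2)c(-c2ccc(OC)cc2)cc1=O`: in a functional assay on HL-60 cells (Homo sapiens) for inhibition (a higher number here means a weaker inhibitor, a lower number a stronger inhibitor), compound 1 gives > 100000 nM, which is a limit of the assay and not a number.
Compound 2, `COc1ccc(-c2cc(=O)n(C)nc2-c2ccc(OC)cc2)cc1`: in this assay compound 2 gives 1130 nM.
Compound 3, `COc1ccc(-c2cc(=O)n(CC3CC3)nc2-c2ccc(OC)cc2)cc1`: in this assay compound 3 gives 1800 nM.

Compound 1 therefore stands at the weak end of what has been seen, and only as a limit (the limit of > 100000 nM in this assay, at which 1 of the 3 values shown sits), so its true number is not known. The unmeasured compound 4, `COc1ccc(-c2cc(=O)n(CC3CCCC3)nc2-c2ccc(OC)cc2)cc1`, differs from compound 1 in one place: cyclopentyl in place of vinyl on a saturated chain carbon bound to an aromatic nitrogen.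

Two measured steps start from the same compound 1 and change the same group. The first gave an at least 88-fold lower number from compound 1 to compound 2 (1.94 log units; beyond the scatter). The second gave an at least 55-fold lower number from compound 1 to compound 3 (1.74 log units; beyond the scatter). The two products of those steps sit close together: a 1.6-fold higher number from compound 2 to compound 3 (0.20 log units; within the scatter). So removing the vinyl, or swapping it for a small saturated ring, gave a large drop in the number both times, and the size of the replacing group mattered little between hydrogen and cyclopropyl. Cyclopentyl is a larger saturated ring than cyclopropyl, and there is no measured step that tests a ring of that size, so the expectation is less firm.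

Still, compound 4 is expected to give a large lower number than compound 1, an at least 33-fold lower number from compound 1 to compound 4 (1.52 log units; beyond the scatter), landing near compounds 2 and 3. The estimate for compound 4 is 3000 nM, within a range from 700 nM to 20000 nM.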

Compound 4, half-maximal inhibitory concentration: 110 nM
Beside the measured number, compound 4's estimate is 27-fold (1.44 log units) above it, outside the stated range (below it).
By their numbers in this assay, from the lowest: compound 4; then compounds 2 and 3 (each within the scatter of the next). At a limit, above all of these: compound 1.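

The earlier compounds shown here suggested that the group on the saturated chain carbon bound to an aromatic nitrogen mattered little once the vinyl was gone, since hydrogen and cyclopropyl gave values within the scatter of each other, but cyclopentyl shows otherwise: in this assay the change gives a 16-fold lower number from compound 3 to compound 4 (1.21 log units; beyond the scatter), and replacing hydrogen gives a 10-fold lower number from compound 2 to compound 4 (1.01 log units; beyond the scatter). This position can therefore do more than avoid the loss seen with vinyl, and of the compounds shown, compound 4 is the strongest inhibitor, with no simple link to group size, as hydrogen and cyclopropyl do not separate and the smaller vinyl of compound 1 sits far on the weak side of hydrogen. Compound 1 is known only as a limit, so an at least 900-fold lower number from compound 1 to compound 4 (2.95 log units; beyond the scatter) gives only the smallest possible size of that step: the limit of > 100000 nM in this assay, at which 1 of the 4 values shown sits.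

The compounds shown leave open whether the gain belongs to the ring itself or simply to more carbon, which an open chain such as pentyl would test. They also leave open whether a larger ring such as cyclohexyl goes further, and whether a ring holding an amine, such as piperidine, is accepted here.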